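This account rests on a few compounds, and the source may have more. Where it says the series, first, only, none or still open, it means among the compounds named here.

Measured so far:
compound 1, `N#Cc1c(N2CCC(c3cccc(F)c3)CC2)ccn(CC2CC2)c1=O`, 141 nM
compound 2, `N#Cc1c(N2CCC(c3ccccc3Cl)CC2)ccn(CC2CC2)c1=O`, 49 nM
compound 3, `COc1ccccc1C1CCN(c2ccn(CC3CC3)c(=O)c2C#N)CC1`, 35 nM

All three share one core and differ only in the aryl group on the saturated ring carbon. In a functional assay on CHO cells for positive allosteric modulation of metabotropic glutamate receptor 2 (Homo sapiens), with a stated time of 30 min (on this read-out lower numbers stand for an effect already at smaller amounts and higher numbers for an effect only at larger amounts of compound), compound 3 gives the lowest number of the three, but its gap to compound 2 is within the scatter (a 1.4-fold lower number from compound 2 to compound 3 (0.15 log units; within the scatter)), so the two cannot be ranked; only compound 1 stands clearly apart (a 4.0-fold lower number from compound 1 to compound 3 (0.61 log units; beyond the scatter), a 2.9-fold lower number from compound 1 to compound 2 (0.46 log units; beyond the scatter)).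

Compound 4, `N#Cc1c(N2CCC(c3cc(F)cc(F)c3)CC2)ccn(CC2CC2)c1=O`, is not yet measured. The change from compound 3 is 3,5-difluorophenyl in place of 2-methoxyphenyl on a saturated ring carbon. Going by the values given here, the one measured step that bears on it directly is the exchange of 3-fluorophenyl for 2-methoxyphenyl, a 4.0-fold lower number from compound 1 to compound 3 (0.61 log units; beyond the scatter); compound 4 runs this step backwards, with a second fluorine added, and no measured pair shows what a second fluorine on the same ring does. The expectation is therefore a step in this assay of about the size of that step, in the opposite direction, towards the number of compound 1: a 3.7-fold higher number from compound 3 to compound 4 (0.57 log units; beyond the scatter) is expected.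

For compound 4 the estimate in this assay is 130 nM, with a range from 55 nM to 320 nM.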

Compound 4, half-maximal effective concentration: 151 nM
Estimate against measurement, compound 4: 1.2-fold (0.07 log units) below; the measured number falls inside the stated range.
By their numbers in this assay, from the lowest: compounds 3 and 2 (each within the scatter of the next); then compounds 1 and 4 (each within the scatter of the next).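

In this assay, a second fluorine on the aryl group at this position, on a saturated ring carbon three ring bonds from the ring nitrogen, leaves no readable change (a 1.1-fold higher number from compound 1 to compound 4 (0.03 log units; within the scatter)). The 3,5-difluorophenyl group nevertheless stays clearly apart from both the 2-methoxyphenyl group (a 4.3-fold higher number from compound 3 to compound 4 (0.63 log units; beyond the scatter)) and the 2-chlorophenyl group (a 3.1-fold higher number from compound 2 to compound 4 (0.49 log units; beyond the scatter)). The four compounds thus form two sets, with 2-chlorophenyl and 2-methoxyphenyl at the lower numbers and 3-fluorophenyl and 3,5-difluorophenyl at the higher, no compound goes against this split, and no supporting data are available to account for it.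

Across these compounds the identity of the aryl substituent and its place on the ring change together, so a 2-fluorophenyl group or a 3-methoxyphenyl group would be needed to tell the two apart. Also open, on these data alone, is how far this position tolerates other groups, such as an unsubstituted phenyl, a 2-methylphenyl or an aryl ring carrying an amine or a carboxylic acid.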